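Lengthening an Amide Chain in a Growth-Inhibition Series

A few compounds are considered here, and "the series" means these few. Any claim that something is new, unique, unknown or untested is made for them only; others in the source may bear on it.

In a functional assay on MCF7 cells (Homo sapiens) for antiproliferative activity, read by CCK-8 assay, with a stated time of 72 h (a higher number here means a weaker inhibitor of growth, a lower number a stronger inhibitor of growth), compound 1 `CC[C@@H]1C(=O)N(C)c2cnc(-n3ccc4ccccc43)nc2N1C1CCCC1` gives 17200 nM and compound 2 `CC[C@@H]1C(=O)N(C)c2cnc(-n3ccc4cc(F)ccc43)nc2N1C1CCCC1` gives "not active" (no number reported) as its result. Among the compounds with values here, compound 3 `CC[C@@H]1C(=O)N(C)c2cnc(-n3ccc4cc(C(=O)NC)ccc43)nc2N1C1CCCC1` gives 1000 nM as the lowest of the two numbers so far. Compound 4 `CCCNC(=O)c1ccc2c(ccn2-c2ncc3c(n2)N(C2CCCC2)[C@H](CC)C(=O)N3C)c1` differs from compound 3 by ethyl in place of hydrogen on a saturated chain carbon bound to an amide-type nitrogen in one place, ethyl in place of hydrogen on a saturated chain carbon bound to an amide-type nitrogen, so methylcarbamoyl becomes propylcarbamoyl. Within the data shown here, the only measured step, a 17-fold lower number from compound 1 to compound 3 (1.24 log units; beyond the scatter) on placing methylcarbamoyl on an aromatic carbon, added the whole group and left its chain unvaried, so it gives no direct guide to size here. In this assay a small change is expected, with a 1.5-fold higher number from compound 3 to compound 4 (0.18 log units; within the scatter) as the estimate. For compound 4 the estimated value is 1500 nM within an expected range of 400 nM to 6000 nM overall.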

Compound 4, concentration for 50% growth inhibition: 592 nM
Beside the measured number, compound 4's estimate is 2.5-fold (0.40 log units) above it; the range from low to high includes it.
By their numbers in this assay, from the lowest: compounds 4 and 3 (each within the scatter of the next); then compound 1.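

Going from methylcarbamoyl to propylcarbamoyl gives a 1.7-fold lower number from compound 3 to compound 4 (0.23 log units; within the scatter) in this assay and so shows that adding ethyl to this amide chain leaves the number within the usual scatter. The large step from hydrogen on the aromatic carbon also holds with the longer chain, as a 29-fold lower number from compound 1 to compound 4 (1.46 log units; beyond the scatter) shows, so it is not tied to methylcarbamoyl alone. Nothing shown here gives a reason for either result.

As far as these compounds go, whether a longer chain such as butylcarbamoyl would hold this level remains open. So does the outcome for a chain ending in an amine or a carboxylic acid.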